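Swapping a Fluorophenyl Ether for a Pyridinyl Ether

A few compounds are considered here, and "the series" means these few. Any claim that something is new, unique, unknown or untested is made for them only; others in the source may bear on it.

Two measured compounds share one core and differ only in the aromatic ring sitting on an oxygen on a saturated carbon. Compound 1 `O=C(c1ccc(F)cc1)N1CCc2nc(COc3cccc(F)c3)oc2C1` carries a 3-fluorophenyl there, and in a functional assay on HEK293 cells for positive allosteric modulation of metabotropic glutamate receptor 5 (Homo sapiens), read by calcium flux (a lower number here means a smaller maximal response, a higher number a larger maximal response), compound 1 gives 78%. Compound 2 `O=C(c1ccc(F)cc1)N1CCc2nc(COc3ccc(F)cc3)oc2C1` carries a 4-fluorophenyl, and in this assay compound 2 gives 73%. The step of a number 5 percentage points lower from compound 1 to compound 2 (within the scatter) stays within the scatter, so compound 2 stands as one of two numbers that cannot be told apart. Compound 3 `O=C(c1ccc(F)cc1)N1CCc2nc(COc3ccccn3)oc2C1` is the untested compound, with pyridin-2-yl in place of 4-fluorophenyl on an oxygen on a saturated carbon. Among the compounds with values here, only one measured step bears on this position, and it was small. Within the data shown here, no measured compound shows what replacing a carbon-only ring by a ring with one nitrogen does, so the expectation rests on the stillness seen so far. The step of a number 5 percentage points lower from compound 2 to compound 3 (within the scatter) is therefore expected to be modest, and compound 3 is estimated at 68%, within 48% to 88%.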

Compound 3, largest response reached (reported as percent of maximum), in percent of the reference or control that the assay uses: 75%
Compound 3: middle estimate off by 7 percentage points, on the low side, and the stated range covers the measured number.
By their numbers in this assay, from the lowest: compounds 2, 3 and 1 (each within the scatter of the next).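

Until now, only the place of the fluorine on the phenyl ring had changed at this position. Compound 3 goes further, with pyridin-2-yl bringing a nitrogen into the ring and adding a hydrogen-bond acceptor, while the fluorine is gone. In this assay this swap gives a number 2 percentage points higher from compound 2 to compound 3 (within the scatter) and also a number 3 percentage points lower from compound 1 to compound 3 (within the scatter) and thus the largest response does not separate pyridin-2-yl from either fluorophenyl ring, and nothing available explains this sameness.

The compounds shown leave open whether a nitrogen elsewhere in the ring, as in pyridin-3-yl or pyridin-4-yl, would behave the same way. They also leave open what a non-aromatic group on this oxygen, such as a piperidine ring, a carboxylic acid or a longer chain, would do to the response.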